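The compounds below may be only part of what the source reports. "The series", "measured", "known", "first", "only" and "open" are said of these compounds alone.

- Compound 1 `CN(C)CCCNc1nc2cc([N+](=O)[O-])ccc2nc1NCc1ccc(C(F)(F)F)cc1`: 5.66 ug/mL
- Compound 2 `O=[N+]([O-])c1ccc2nc(NCc3ccc(C(F)(F)F)cc3)c(N3CCNCC3)nc2c1`: 9.61 ug/mL

In an ADME assay on HEK293 cells (Homo sapiens) for cytotoxicity, read by MTT assay, with a stated time of 24 h (on this read-out higher numbers stand for weaker inhibition and lower numbers for stronger inhibition), compound 1 gives 5.66 ug/mL. Among the compounds with values here, only one other number stands beside it, and the comparison is a 1.7-fold higher number from compound 1 to compound 2 (0.23 log units; within the scatter), so the two compounds cannot be told apart.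

Compound 3 `CN(C)CCCNc1nc2cc([N+](=O)[O-])ccc2nc1NCc1ccccc1Br` is still unmeasured. Compared with compound 1, it carries 2-bromophenyl in place of 4-(trifluoromethyl)phenyl on a saturated chain carbon bound to a nitrogen on an aromatic ring.

Within the data shown here, the one measured step swaps a different group, piperazin-1-yl in place of (3-(dimethylamino)propyl)amino on an aromatic carbon, so it bears only indirectly. Among the measured compounds shown here, no measured pair shows a change at the new place. The best anchor is therefore compound 1 at 5.66 ug/mL, and no step beyond the scatter is expected, in either direction.

The expected result is a 1.1-fold higher number from compound 1 to compound 3 (0.03 log units; within the scatter). Compound 3 is estimated at 6 ug/mL, with an expected range of 2.5 ug/mL to 14 ug/mL.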

Compound 3, half-maximal inhibitory concentration: 51.9 ug/mL
Beside the measured number, compound 3's estimate is 8.7-fold (0.94 log units) below it; measured number above the stated range.
By their numbers in this assay, from the lowest: compounds 1 and 2 (each within the scatter of the next); then compound 3.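

The earlier step changed only the amine-bearing group on the aromatic carbon and stayed within the scatter, so it said nothing about the aryl group on the saturated chain carbon. In this assay, 2-bromophenyl in place of 4-(trifluoromethyl)phenyl gives a 9.2-fold higher number from compound 1 to compound 3 (0.96 log units; beyond the scatter), which on this read-out means weaker inhibition, so this position can move the number beyond the scatter. No measurement here accounts for the size of this step.

This single swap changes both the substituent and where it sits on the phenyl ring, so the two changes cannot be separated; 4-bromophenyl or 2-(trifluoromethyl)phenyl would each alter only one of them. An unsubstituted phenyl group would show how either substituent compares with a plain ring.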